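The source may report more compounds than this note shows. Statements on the series, on what has been measured and on what is new or still open speak of the compounds shown alone.

Measured so far in an assay on isolated protein for inhibition of ceramide glucosyltransferase (Homo sapiens); a higher number here means a weaker inhibitor, a lower number a stronger inhibitor:
compound 1, `COc1ccccc1-c1ccc(COCCCCCN2C[C@H](O)[C@@H](O)[C@H](O)[C@H]2CO)cc1`: 50 nM
compound 2, `OC[C@@H]1[C@@H](O)[C@H](O)[C@@H](O)CN1CCCCCOCc1ccc(-c2ccc3c(c2)OCCO3)cc1`: 40 nM

Going by the values given here, compound 1 stands at the upper end of the two numbers as measured, but the single step available, a 1.3-fold lower number from compound 1 to compound 2 (0.10 log units; within the scatter), lies within the scatter, so no order between the two compounds is claimed. That step exchanges the 2-methoxyphenyl group on an aromatic carbon of the shared core for another aromatic group, with the rest of the molecule kept.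

Compound 3, `OC[C@@H]1[C@@H](O)[C@H](O)[C@@H](O)CN1CCCCCOCc1ccc(-c2ccc(F)nc2)cc1`, is not yet measured. Relative to compound 1 the change is 6-fluoropyridin-3-yl in place of 2-methoxyphenyl on an aromatic carbon. Among the compounds with values here, the only comparison that bears on this is a 1.3-fold lower number from compound 1 to compound 2 (0.10 log units; within the scatter), which likewise swaps the same 2-methoxyphenyl group at that aromatic carbon for a different aromatic group and stayed within the scatter. Within the data shown here, no other measured step exists. The expected step of a 1.1-fold higher number from compound 1 to compound 3 (0.04 log units; within the scatter) in this assay is therefore none beyond the scatter, in either direction. Compound 3 is estimated at 55 nM in this assay, with a range from 25 nM to 120 nM.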

Compound 3, half-maximal inhibitory concentration: 750 nM
Compound 3: the middle estimate sits 14-fold (1.13 log units) below what was measured; the measured number lies above the stated range.
By their numbers in this assay, from the lowest: compounds 2 and 1 (each within the scatter of the next); then compound 3.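

In this assay this aromatic carbon of the shared core is not indifferent to the group it carries: 6-fluoropyridin-3-yl in place of 2-methoxyphenyl gives a 15-fold higher number from compound 1 to compound 3 (1.18 log units; beyond the scatter) and in place of 2,3-dihydro-1,4-benzodioxin-6-yl gives a 19-fold higher number from compound 2 to compound 3 (1.27 log units; beyond the scatter), so compound 3 is a clearly weaker inhibitor than either of the other two. The earlier exchange at this carbon left no difference beyond the scatter, so not every replacement of the 2-methoxyphenyl group is tolerated, even though the group entering in compound 3 matches the one leaving in its counts of hydrogen-bond donors and acceptors and in net charge. Nothing at hand accounts for the higher number of compound 3.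

The ring nitrogen and the fluorine enter together, so the compounds shown leave open which of them goes with the higher number; a plain pyridinyl group and a fluorophenyl group at this carbon would separate the two. Also open, going by these compounds, is whether a methoxypyridinyl group, which pairs the ring nitrogen with the methoxy group of compound 1, would stay near compound 1 or move towards compound 3.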